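Benzoyl in place of acetyl on the amidomethyl arm

The source may report more compounds than this note shows. Statements on the series, on what has been measured and on what is new or still open speak of the compounds shown alone.

Two members of this disaccharide series carrying a phenyl-lactic acid side chain have been measured in an assay on isolated protein for inhibition of E-selectin (Homo sapiens); on this read-out higher numbers stand for weaker inhibition and lower numbers for stronger inhibition. Compound 1 `CC1OC(OC2CCCCC2OC2OC(CN)C(O)C(O[C@@H](Cc3ccccc3)C(=O)O)C2O)C(O)C(O)C1O` gives only a limit of the assay, > 10000000 nM. Compound 2 `CC(=O)NCC1OC(OC2CCCCC2OC2OC(C)C(O)C(O)C2O)C(O)C(OC(Cc2ccccc2)C(=O)O)C1O` gives likewise only a limit, > 10000000 nM. For the measured compounds named here, compound 2 thus stands at the same limit as the one other value shown; no number separates the two, and the whole record is the limit of > 10000000 nM in this assay, at which 2 of the 2 values shown sit.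

Compound 3 `CC1OC(OC2CCCCC2OC2OC(CNC(=O)c3ccccc3)C(O)C(OC(Cc3ccccc3)C(=O)O)C2O)C(O)C(O)C1O` differs from compound 2 in one place: phenyl in place of methyl on a carbonyl carbon, read one bond further out as acetamidomethyl to benzamidomethyl. Going by the values given here, no measured pair spans this change, so neither size nor direction of the step is known from the data. Because both measured values sit at the limit of > 10000000 nM in this assay, at which 2 of the 2 values shown sit, the step from compound 2 to compound 3 is expected at about a number no higher from compound 2 to compound 3 (the limit leaves the size open), with a limit again the most probable report. Compound 3 is estimated at 10000000 nM, between 1000000 nM and 30000000 nM.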

Compound 3, half-maximal inhibitory concentration: > 10000000 nM
Compound 3: no number, only a limit; the forecaster's own chance of this, stated with the estimate: 80%; the middle value sits exactly at the limit.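

Compound 2 and compound 3 both report only a limit, so no step can be read for acetamidomethyl to benzamidomethyl: the limit of > 10000000 nM in this assay, at which 3 of the 3 values shown sit. The compounds shown leave open whether phenyl in place of methyl on a carbonyl carbon changes inhibition at all in this assay.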